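This account rests on a few compounds, and the source may have more. Where it says the series, first, only, none or still open, it means among the compounds named here.

Notes on the series. Compound 1 `CC(C)(C)n1nc(Oc2cc(C#N)ccn2)c2c(N)ncnc21` carries a tert-butyl and a nitrile; compound 2 `Nc1ncnc2c1c(Oc1cc(Cl)ccn1)nn2[C@H]1C[C@H](F)C1` carries a 3-fluorocyclobutyl and a chlorine; compound 3 `CC(C)(C)n1nc(Oc2cc(Cl)ccn2)c2c(N)ncnc21` awaits measurement. Within the data shown here, in an ADME assay on microsomes from liver (Homo sapiens) for metabolic stability, read by LC-MS, using NADPH, with a stated time of 10 min, tested at 10 uM (on this read-out lower numbers stand for a shorter-lived compound and higher numbers for a longer-lived compound), compound 2 gives 0.833 h, the only number so far. For compound 1 this assay reports a limit, > 2.41 h. Compound 3 differs from compound 2 by tert-butyl in place of 3-fluorocyclobutyl on an aromatic nitrogen. Among the measured compounds shown here, no step between measured compounds is available. The step of a 2.4-fold higher number from compound 2 to compound 3 (0.38 log units; beyond the scatter) is expected to be upward and beyond the scatter, given compound 1 sitting at the limit of > 2.41 h in this assay, at which 1 of the 2 values shown sits. Compound 3 is estimated at 2 h, within 1 h to 4 h.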

Compound 3, half-life: 1 h
For compound 3 the middle estimate is 2.0-fold (0.30 log units) above the measured one, within the range that was stated.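

In this assay, the change on the aromatic nitrogen gives a 1.2-fold higher number from compound 2 to compound 3 (0.08 log units; within the scatter), so tert-butyl and 3-fluorocyclobutyl are not separated at this position when chlorine is present. With tert-butyl held, chloro in place of cyano on an aromatic carbon gives an at least 2.4-fold lower number from compound 1 to compound 3 (0.38 log units; beyond the scatter), so this pair shows a difference beyond the scatter. Compound 1 is reported only as a limit of the assay: the limit of > 2.41 h in this assay, at which 1 of the 3 values shown sits.

Going by these compounds, whether the nitrile gives a similar step alongside 3-fluorocyclobutyl remains open. Also open, on these data alone, is how an amine on that aromatic carbon, or a longer chain on the aromatic nitrogen, would read.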